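The source may hold more compounds than are shown below. What is called first, only, known or untested is meant among the compounds shown, and "the series" means these compounds.

In an assay on cells with melanin-concentrating hormone receptor 1 (Homo sapiens) as the target, read by radioligand binding (a lower number here means a stronger inhibitor, a higher number a weaker inhibitor), compound 1 `CCOCCOc1cccc2ccc(N)nc12` gives only a limit of > 2000 nM. Compound 2 `CC#CCCOc1cccc2ccc(N)nc12` likewise gives only a limit of > 2000 nM. Going by the values given here, compound 3 `CC1CCC(Oc2cccc3ccc(N)nc23)C1` is the sole compound with a number in this assay, 823 nM. The step from compound 1 to compound 2 is a step that the two limits leave unreadable from compound 1 to compound 2, while an at least 2.4-fold lower number from compound 1 to compound 3 (0.38 log units; beyond the scatter) and an at least 2.4-fold lower number from compound 2 to compound 3 (0.38 log units; beyond the scatter) both favour the 3-methylcyclopentyl ether. Compound 4 `Nc1ccc2cccc(OCC3CCOC3)c2n1` differs by (oxolan-3-yl)methyl in place of 3-methylcyclopentyl on an oxygen on an aromatic ring. The step of a 3.0-fold higher number from compound 3 to compound 4 (0.48 log units; beyond the scatter) is expected to run towards a weaker inhibitor, because an at least 2.4-fold lower number from compound 1 to compound 3 (0.38 log units; beyond the scatter) shows that leaving the carbocycle for a chain bearing 2-ethoxyethyl cost potency. For compound 4 the estimate in this assay is 2500 nM, between 800 nM and 8000 nM.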

Compound 4, half-maximal inhibitory concentration: 115 nM
The estimate for compound 4 lay 22-fold (1.34 log units) above the measured number, outside the stated range (below it).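

In this assay, the (oxolan-3-yl)methyl group beats the carbocycle, with a 7.2-fold lower number from compound 3 to compound 4 (0.85 log units; beyond the scatter), so an oxygen in the group carries no penalty as such when it sits in a five-membered ring. Against the open chains the steps are large, with an at least 17-fold lower number from compound 2 to compound 4 (1.24 log units; beyond the scatter) and an at least 17-fold lower number from compound 1 to compound 4 (1.24 log units; beyond the scatter). These two steps are lower bounds, as compounds 1 and 2 each give only a limit: the limit of > 2000 nM in this assay, at which 2 of the 4 values shown sit.

Still open, from the compounds shown here alone, is whether the gain follows the ring oxygen or the methyl link, which cyclopentylmethyl would separate. Also open, going by these compounds, is whether a pyrrolidine ring, with an amine in place of that oxygen, would keep it.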